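Swapping Fluoro for Chloro on Two Different Rings

The source may report more compounds than this note shows. Statements on the series, on what has been measured and on what is new or still open speak of the compounds shown alone.

Compound 1 `CC(C)(C)C1=NN(c2cccc(Cl)c2)C(c2ccc(O)cc2)C1` gives 43.5% in an assay on isolated protein for inhibition of protein kinase C iota type (Homo sapiens), tested at 20 uM; a lower number here means less inhibition, a higher number more inhibition at the concentration tested (going by the name of the read-out). Compound 2 `CC(C)(C)C1=NN(c2cccc(F)c2)C(c2ccc(O)cc2)C1` gives 19.3% in this assay, and compound 3 `CC(C)(C)C1=NN(c2ccc(Cl)cc2)C(c2ccc(O)c(F)c2)C1` gives 29.7% in this assay. From compound 2 to compound 1 the change is chloro in place of fluoro on an aromatic carbon, and this brought a number 24.2 percentage points higher from compound 2 to compound 1 (beyond the scatter). The difference between the cores of compound 2 and compound 3 is not broken down here. Compound 4 `CC(C)(C)C1=NN(c2ccc(Cl)cc2)C(c2ccc(O)c(Cl)c2)C1` has not been measured yet; relative to compound 3 the change is chloro in place of fluoro on an aromatic carbon. This is the same kind of change, though the place differs: here it is ortho to a hydroxy group as well as meta to a large group. For compound 4 in this assay a step of a number 15.3 percentage points higher from compound 3 to compound 4 (beyond the scatter) is expected, a rise resting on a number 24.2 percentage points higher from compound 2 to compound 1 (beyond the scatter). The place is not identical, so a smaller rise is expected. Compound 4 is therefore estimated at 45%, between 25% and 65%.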

Compound 4, a percentage reported as inhibition, at one concentration (the size of the read-out at that concentration, not a potency): 0%
Estimate against measurement, compound 4: 45 percentage points above, and the stated range ends above it.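

Chloro in place of fluoro did not carry over from one core to the other in this assay, giving a number 29.7 percentage points lower from compound 3 to compound 4 (beyond the scatter). The earlier step went the opposite way, so the two results disagree in direction: the same change on two cores in this assay, a number 24.2 percentage points higher (beyond the scatter) from compound 2 to compound 1 and a number 29.7 percentage points lower (beyond the scatter) from compound 3 to compound 4, 53.9 percentage points apart, beyond the scatter of two such steps. This shows that the result of this swap on one core cannot be assumed for another in this series, but two pairs do not show whether the place of the swap or the rest of the molecule decides the outcome.

The compounds shown leave open how an amine, a methoxy group or a carboxylic acid would read in place of the chloro of the 3-chloro-4-hydroxyphenyl group. They also leave open whether bromo would follow chloro or fluoro there.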